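The source may report more compounds than this note shows. Statements on the series, on what has been measured and on what is new or still open speak of the compounds shown alone.

Compound 1 `O=C1c2ccc(O)cc2O[C@@H](c2cccc(O)c2O)[C@@H]1O`: > 100000 nM, a limit
Compound 2 `O=C1c2ccccc2O[C@@H](c2cccc(O)c2O)[C@@H]1O`: > 100000 nM, a limit

In a functional assay on RAW264.7 cells (Rattus norvegicus) for inhibition, with RAW264.7 (Mus musculus) as the target, read by Griess assay, with stated times of 2 h and 16 h (a higher number here means a weaker inhibitor, a lower number a stronger inhibitor), compound 2 stands at > 100000 nM, which is a limit of the assay and not a number. Compound 3 `O=C1c2ccccc2O[C@H](c2cccc(O)c2O)[C@H]1O` is related to compound 2 as follows: the two compounds have the same atoms and bonds and differ only in configuration as drawn: 2 of 2 stereo elements differ (all stereocentres are inverted: mirror images); a stereocentre at a saturated ring carbon is drawn S in compound 2 and R in compound 3; a stereocentre at a saturated ring carbon is drawn S in compound 2 and R in compound 3. Within the data shown here, no measured pair here tests a change of configuration. Among the measured compounds shown here, the one measured step is a step that the two limits leave unreadable from compound 1 to compound 2, with hydrogen in place of hydroxy on an aromatic carbon, so it offers no size to carry over. Both measured compounds share one position, (the limit of > 100000 nM in this assay, at which 2 of the 2 values shown sit). For the measured compounds named here, no step of readable size or direction can therefore be derived for this assay, and compound 3 is expected to stay weak, most likely at the same limit. The expected change is a number no higher from compound 2 to compound 3 (the limit leaves the size open), and this is only an estimate. For compound 3 the estimated value is 100000 nM, with an expected range from 30000 nM to 200000 nM.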

Compound 3, half-maximal inhibitory concentration: > 100000 nM
Compound 3: no number, only a limit; the forecaster's own chance of this, stated with the estimate: 70%; the middle value sits exactly at the limit.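

In this assay compound 3 gives > 100000 nM, which is a limit of the assay and not a number. Among these compounds, compound 2 also sits at a limit, so no step between compound 2 and compound 3 can be read. The compounds shown leave open whether configuration affects inhibition at all.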